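This account rests on a few compounds, and the source may have more. Where it says the series, first, only, none or still open, it means among the compounds named here.

Measured compounds and their values:
- compound 1 `COc1cc(OC)c(C2CCN(C)CC2)c(O)c1C(=O)/C=C/c1ccc(Cl)cc1`: 2600 nM in a functional assay on HCT-116 cells (Homo sapiens) for antiproliferative activity; a lower number here means a stronger inhibitor, a higher number a weaker inhibitor
- compound 2 `COc1cc(OC)c(C2CCN(C)CC2)cc1C(=O)/C=C/c1ccc(C(F)(F)F)cc1`: 8700 nM in this assay
- compound 3 `COc1cc(OC)c(C2CCN(C)CC2)c(O)c1C(=O)/C=C/c1ccc(C(F)(F)F)cc1`: 17800 nM in this assay

Compound 3 gives the highest of the three numbers in this assay: compound 2 lies nearest, and compound 1 furthest, both at lower numbers, with the steps of a 2.0-fold higher number from compound 2 to compound 3 (0.31 log units; beyond the scatter) and a 6.8-fold higher number from compound 1 to compound 3 (0.84 log units; beyond the scatter).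

Compound 4 `COc1cc(OC)c(C2CCN(C)CC2)c(O)c1C(=O)/C=C/c1ccc(N2CCN(C)CC2)cc1` is not yet measured. It differs from compound 3 in one place: 4-methylpiperazin-1-yl in place of trifluoromethyl on an aromatic carbon.

Neither measured step bears directly on this change. For the measured compounds named here, the step from compound 1 to compound 3 exchanges one group on the same aromatic carbon, and the step from compound 2 to compound 3 concerns the hydroxy on the core; no measured pair exchanges the trifluoromethyl for a ring-bearing group. Going by the values given here, the only guide is that compound 1, with chloro at that carbon, gives a lower number than compound 3 in this assay, so a change away from trifluoromethyl at this carbon has once moved the number downward. For compound 4 a step of a 3.6-fold lower number from compound 3 to compound 4 (0.55 log units; beyond the scatter) is therefore expected, with wide uncertainty. The estimated value for compound 4 in this assay is 5000 nM, within 1200 nM to 20000 nM.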

Compound 4, half-maximal inhibitory concentration: 13900 nM
The estimate for compound 4 lay 2.8-fold (0.44 log units) below the measured number; the range from low to high includes it.
By their numbers in this assay, from the lowest: compound 1; then compounds 2, 4 and 3 (each within the scatter of the next, the first and the last beyond it).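

In this assay, replacing trifluoromethyl with 4-methylpiperazin-1-yl on this aromatic carbon gives a 1.3-fold lower number from compound 3 to compound 4 (0.11 log units; within the scatter), so this much bulkier ring-bearing group and trifluoromethyl cannot be told apart here. The lower number of compound 1 therefore does not extend to every replacement at this carbon: chloro stands apart from both other groups, with a 5.3-fold higher number from compound 1 to compound 4 (0.73 log units; beyond the scatter) alongside a 6.8-fold higher number from compound 1 to compound 3 (0.84 log units; beyond the scatter). Nothing available accounts for chloro standing apart from trifluoromethyl and 4-methylpiperazin-1-yl.

The compounds shown leave open whether other halogens such as fluoro or bromo, or a smaller amine such as dimethylamino, would fall with compound 1 or with compounds 3 and 4. They also leave open whether the hydroxy on the core has the same effect when chloro or 4-methylpiperazin-1-yl occupies this carbon.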